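Hydroxymethyl Oxadiazole in Place of Isopropyl Thiadiazole

This account rests on a few compounds, and the source may have more. Where it says the series, first, only, none or still open, it means among the compounds named here.

Of the compounds shown here, two have been measured so far in an assay on microsomes from liver for inhibition of acyl-CoA desaturase 1 (Rattus norvegicus); on this read-out lower numbers stand for stronger inhibition and higher numbers for weaker inhibition. Compound 1 `CC(C)c1nnc(-c2ccc(N3CCC(Oc4ccccc4C(F)(F)F)CC3)nn2)s1` gives 8.8 nM in this assay, the higher of the two numbers. Compound 2 `CCc1ccccc1OC1CCN(c2ccc(-n3ccnc3)nn2)CC1`, which carries a different group on the shared core, gives 4 nM in this assay; the gap between the two lies beyond the usual scatter, so compound 1 is the weaker inhibitor of this pair.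

The step under study leads to compound 3 `OCc1nnc(-c2ccc(N3CCC(Oc4ccccc4C(F)(F)F)CC3)nn2)o1`, which has not been measured yet. Its structure differs from compound 1 in one place: 5-(hydroxymethyl)-1,3,4-oxadiazol-2-yl in place of 5-isopropyl-1,3,4-thiadiazol-2-yl on an aromatic carbon. Within the data shown here, no pair of measured compounds shares this change, so nothing measured yet shows what it does.

The expected outcome is a moderate move toward a higher number in this assay, that is toward weaker inhibition, estimated as a 3.4-fold higher number from compound 1 to compound 3 (0.53 log units; beyond the scatter) and expected to lie beyond the scatter. Compound 3 is therefore estimated at 30 nM in this assay, with a plausible range from 8 nM to 120 nM.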

Compound 3, half-maximal inhibitory concentration: 2.9 nM
Estimate against measurement, compound 3: 10-fold (1.01 log units) above; the whole stated range lies above it.
By their numbers in this assay, from the lowest: compounds 3 and 2 (each within the scatter of the next); then compound 1.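

In this assay the move from 5-isopropyl-1,3,4-thiadiazol-2-yl to 5-(hydroxymethyl)-1,3,4-oxadiazol-2-yl gives a 3.0-fold lower number from compound 1 to compound 3 (0.48 log units; beyond the scatter) and so a modest gain in inhibition that lies beyond the scatter. Among these compounds, this is the first sign that this position, on an aromatic carbon para to a large group, accepts a substantial change without loss of inhibition: the group that leaves has 0 hydrogen-bond donors and 3 acceptors, while the group that enters has 1 donor and 4 acceptors. Nothing on hand explains why the number falls, so the step stands as an observation only.

The step changes two things at once, the ring and the chain on it, so the compounds shown cannot say whether the gain comes from the oxadiazole ring, from the hydroxymethyl group, or only from the two together. Open as well is how the position would respond to a 5-isopropyl-1,3,4-oxadiazol-2-yl group, a 5-(hydroxymethyl)-1,3,4-thiadiazol-2-yl group, or an oxadiazole carrying an amine or a carboxylic acid in place of the hydroxymethyl group.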